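Ester-to-amide swap at the carbonyl of compound 2

The source may hold more compounds than are shown below. What is called first, only, known or untested is meant among the compounds shown, and "the series" means these compounds.

The series shares one core. Compound 1 `CCn1c(C(=O)NCC#N)ccc1C(CC)(CC)c1ccc(OCCC(O)(CC)CC)c(C)c1` carries a cyanomethyl amide, compound 2 `C#CCCOC(=O)c1ccc(C(CC)(CC)c2ccc(OCCC(O)(CC)CC)c(C)c2)n1CC` a but-3-yn-1-yl ester, and compound 3 `CCOC(=O)CN(C)C(=O)c1ccc(C(CC)(CC)c2ccc(OCCC(O)(CC)CC)c(C)c2)n1CC` a tertiary amide. In a functional assay on PC-3 cells (Homo sapiens) for antiproliferative activity, read by MTT assay, with a stated time of 48 h (a higher number here means a weaker inhibitor, a lower number a stronger inhibitor), compound 1 gives 17800 nM and compound 3 gives 7140 nM. Compound 2 gives only a limit, > 50000 nM, in this assay. Compound 2 therefore sits at the weak end of the numbers shown, at the limit of > 50000 nM in this assay, at which 1 of the 3 values shown sits. Compound 4 `CCn1c(C(=O)N(C)CCO)ccc1C(CC)(CC)c1ccc(OCCC(O)(CC)CC)c(C)c1` differs from compound 2 by (2-hydroxyethyl)(methyl)amino in place of (but-3-yn-1-yl)oxy on a carbonyl carbon. Bearing on this step are an at least 7.0-fold lower number from compound 2 to compound 3 (0.84 log units; beyond the scatter) and an at least 2.8-fold higher number from compound 1 to compound 2 (0.44 log units; beyond the scatter), both favouring the amides over the ester. A step of similar size toward a lower number is expected: compound 4 is estimated at 10000 nM, range 4000 nM to 30000 nM, which means an at least 5.0-fold lower number from compound 2 to compound 4 (0.69 log units; beyond the scatter).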

Compound 4, half-maximal inhibitory concentration: 3090 nM
Compound 4: the middle estimate sits 3.2-fold (0.51 log units) above what was measured; the whole stated range lies above it.
By their numbers in this assay, from the lowest: compound 4; then compound 3; then compound 1. At a limit, above all of these: compound 2.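

In this assay, (2-hydroxyethyl)(methyl)amino on the carbonyl carbon gives an at least 16-fold lower number from compound 2 to compound 4 (1.20 log units; beyond the scatter), and this step is a lower bound, as compound 2 gives only a limit: the limit of > 50000 nM in this assay, at which 1 of the 4 values shown sits. The amides also separate among themselves: hydroxymethyl in place of ethoxycarbonyl on the saturated chain gives a 2.3-fold lower number from compound 3 to compound 4 (0.36 log units; beyond the scatter), and the swap from (cyanomethyl)amino gives a 5.8-fold lower number from compound 1 to compound 4 (0.76 log units; beyond the scatter). Compound 4 is therefore the strongest of the four compounds.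

Still open, as far as these compounds go, is whether a longer chain ending in hydroxyl, or a chain ending in a carboxylic acid or an amine, on this carbonyl carbon would lower the number further.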